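This account rests on a few compounds, and the source may have more. Where it says the series, first, only, none or still open, it means among the compounds named here.

Compound 1 `CN(C)CCCCCn1c2c(c3ccccc31)C(=O)c1c[n+]([O-])c3ccccc3c1C2=O` carries a 5-(dimethylamino)pentyl group on the aromatic nitrogen of the shared core. In a toxicity assay on HEK-293T cells (Homo sapiens) for cytotoxicity, read by MTT assay, with a stated time of 72 h (a higher number here means a weaker inhibitor, a lower number a stronger inhibitor), compound 1 gives 70 nM, the lowest of the three numbers measured; compound 3 `CC1(C)O[C@@H](CO)[C@H](Cn2cc(Cn3c4c(c5ccccc53)C(=O)c3c[n+]([O-])c5ccccc5c3C4=O)nn2)O1`, at 120 nM, lies within the scatter of it, while compound 2 `O=C1c2c[n+]([O-])c3ccccc3c2C(=O)c2c1c1ccccc1n2Cc1cn([C@@H]2C[C@H](O)[C@@H](CO)O2)nn1`, at 820 nM, lies beyond. The one step among these compounds, a 6.8-fold lower number from compound 2 to compound 3 (0.83 log units; beyond the scatter), shows that exchanging the group on that nitrogen shifts this assay modestly. Compound 4 `O=C1c2c[n+]([O-])c3ccccc3c2C(=O)c2[nH]c3ccccc3c21` differs from compound 1 by hydrogen in place of 5-(dimethylamino)pentyl on an aromatic nitrogen. Because compound 1 gives the lowest number at 70 nM and only that nitrogen substituent is changed, a modest rise in the number is expected for compound 4, a 3.6-fold higher number from compound 1 to compound 4 (0.55 log units; beyond the scatter). Compound 4 is therefore estimated at about 250 nM, between 70 nM and 900 nM.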

Compound 4, half-maximal inhibitory concentration: 890 nM
The estimate for compound 4 lay 3.6-fold (0.55 log units) below the measured number; the range from low to high includes it.
By their numbers in this assay, from the lowest: compounds 1 and 3 (each within the scatter of the next); then compounds 2 and 4 (each within the scatter of the next).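

In this assay, a 13-fold higher number from compound 1 to compound 4 (1.10 log units; beyond the scatter) shows that the number at this aromatic nitrogen depends not only on which substituent is present but also on whether one is present at all, a comparison the earlier exchange of one substituent for another could not make. Hydrogen in place of 5-(dimethylamino)pentyl is a large change here. Nothing shown gives a reason for this step. The compounds shown leave open whether the dimethylamino group or the chain carries the difference. A plain pentyl chain, or a shorter chain ending in the same amine, would separate the two.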